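The compounds below may be only part of what the source reports. "The series", "measured", "known", "first", "only" and "open" are said of these compounds alone.

In a functional assay on MV4-11 cells (Homo sapiens) for antiproliferative activity, read by resazurin assay, with a stated time of 72 h (a higher number here means a weaker inhibitor, a lower number a stronger inhibitor), the measured compounds are:

Compound 1 `N#Cc1c(-c2ccco2)nc2c(c(-c3ccccc3)nn2-c2ccccc2)c1-c1ccc(O)cc1`: 13800 nM
Compound 2 `COc1ccc(-c2nc3c(c(-c4ccccc4)nn3-c3ccccc3)c(-c3ccc(O)cc3)c2C#N)cc1`: 1600 nM
Compound 3 `COc1ccc(-c2c(C#N)c(-c3ccccc3)nc3c2c(-c2ccccc2)nn3-c2ccccc2)cc1OC`: the result > 25000 nM is a limit of the assay, not a number.

Compound 1 stands highest of the two numbers shown; the nearest is compound 2, reached by an 8.6-fold lower number from compound 1 to compound 2 (0.94 log units; beyond the scatter). Compound 4 `N#Cc1c(-c2ccc(Cl)cc2)nc2c(c(-c3ccccc3)nn2-c2ccccc2)c1-c1ccc(O)cc1` differs from compound 1 by 4-chlorophenyl in place of furan-2-yl on an aromatic carbon. Among the measured compounds shown here, the one measured step that bears on this change is the one from compound 1 to compound 2, where a six-membered carbon ring also replaced furan-2-yl and gave an 8.6-fold lower number from compound 1 to compound 2 (0.94 log units; beyond the scatter). A lower number for compound 4 is therefore expected, though the size of the step is uncertain. For compound 4 the estimate is 3000 nM, between 800 nM and 11000 nM, which means an expected 4.6-fold lower number from compound 1 to compound 4 (0.66 log units; beyond the scatter).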

Compound 4, half-maximal inhibitory concentration: 25100 nM
For compound 4 the middle estimate is 8.4-fold (0.92 log units) below the measured one; measured number outside the range, above it.
By their numbers in this assay, from the lowest: compound 2; then compounds 1 and 4 (each within the scatter of the next).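

In this assay, swapping furan-2-yl for a six-membered aromatic ring at this place does not by itself lower the number (a 1.8-fold higher number from compound 1 to compound 4 (0.26 log units; within the scatter)). What that ring carries matters far more: with chloro in place of methoxy, the gain seen in compound 2 is gone (a 16-fold higher number from compound 2 to compound 4 (1.20 log units; beyond the scatter)). Compound 3 gives only a limit of the assay, and the number for compound 4 lies close to it: the limit of > 25000 nM in this assay, at which 1 of the 4 values shown sits.

Only methoxy and chloro are shown on this ring. From the compounds shown here alone, whether an amine, a carboxylic acid or a longer alkoxy chain there would match compound 2 remains open.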